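The source may hold more compounds than are shown below. What is called first, only, known or untested is meant among the compounds shown, and "the series" means these compounds.

Notes on the series

The compounds share one core. Compound 1 `O=C1/C(=C/c2ccc(F)cc2)Cc2cc(O)ccc21` gives 47 nM in an assay on isolated protein for inhibition of Amine oxidase [flavin-containing] B (Homo sapiens), read by fluorescence and spectrophotometry, with a stated time of 20 min; a lower number here means a stronger inhibitor, a higher number a weaker inhibitor. Compound 2 `Cc1cccc(/C=C2\Cc3cc(O)ccc3C2=O)c1` gives 52 nM in this assay, and compound 3 `O=C1/C(=C/c2ccc(Cl)c(Cl)c2)Cc2cc(O)ccc21` gives 14 nM. Compound 2 holds the highest number of the three; its gap to compound 1 lies within the usual scatter, so no order between these two can be read from the numbers, while compound 3 sits at a lower number than compound 2 by a gap beyond the scatter.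

The step under consideration leads from compound 2 to compound 4 `COc1cccc(/C=C2\Cc3cc(O)ccc3C2=O)c1`, which has not yet been measured in this assay. The change is methoxy in place of methyl on an aromatic carbon. Within the data shown here, no pair among the measured compounds shows this exchange, so the size of the step cannot be taken from a measured step in this set. The exchange keeps the group on the same aromatic carbon and adds one oxygen, and nothing measured here points to a large move in either direction. The expectation is a step from compound 2 to compound 4 of a 1.3-fold higher number from compound 2 to compound 4 (0.13 log units; within the scatter), not clearly beyond the scatter, with a slight lean toward a higher number. Compound 4 is therefore estimated at 70 nM in this assay, within a range from 25 nM to 200 nM.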

Compound 4, half-maximal inhibitory concentration: 471 nM
For compound 4 the middle estimate is 6.7-fold (0.83 log units) below the measured one; the whole stated range lies below it.
By their numbers in this assay, from the lowest: compound 3; then compounds 1 and 2 (each within the scatter of the next); then compound 4.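

In this assay, methoxy in place of methyl on this aromatic carbon, meta to a large group, gives a step well beyond the usual scatter (a 9.1-fold higher number from compound 2 to compound 4 (0.96 log units; beyond the scatter)), so this exchange at this position is far from neutral. The earlier compounds shown here could not show this: no two of them formed a measured step, and their numbers alone gave no sign that a small change at this carbon could move the number so far. No measurement at hand bears on the reason for the step.

Going by these compounds, it remains open whether ethyl, hydroxy or an amine on the same aromatic carbon would give a number close to that of compound 2, close to that of compound 4, or a different one, so the result cannot yet be tied to any single feature of the entering group. Also open, on these data alone, is whether methoxy on another carbon of this aromatic ring, or the same exchange with other groups present on that ring, would give a step of similar size, since one pair fixes no pattern for the series.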